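Working notes: carboxamide cyclobutyl replacing oxanylethyl on ring nitrogen

A few compounds are considered here, and "the series" means these few. Any claim that something is new, unique, unknown or untested is made for them only; others in the source may bear on it.

Measured compounds:
compound 1 `N#Cc1cnc(NCc2cnccc2C(F)(F)F)cc1NC[C@H]1C[C@H](O)C1` gives > 10000 nM in an assay on isolated protein for inhibition of protein kinase C delta type (Homo sapiens), read by TR-FRET, with a stated time of 2 h; on this read-out higher numbers stand for weaker inhibition and lower numbers for stronger inhibition; this is a limit of the assay.
compound 2 `N#Cc1cnc(NCc2cnccc2C(F)(F)F)cc1NCCC1CCOCC1` gives > 10000 nM in this assay; this too is a limit of the assay.
compound 3 `CC1(C)[C@@H](C(N)=O)C[C@H]1Nc1cc(NCc2cnccc2C(F)(F)F)ncc1C#N` is not yet measured in this assay.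

Compound 2 stands at the limit of the assay, the point where both values shown sit (the limit of > 10000 nM in this assay, at which 2 of the 2 values shown sit). For the measured compounds named here, the single measured step, a step that the two limits leave unreadable from compound 1 to compound 2, cannot be read: both of its ends are limits. The change to compound 3 is 3-carbamoyl-2,2-dimethylcyclobutyl in place of 2-(oxan-4-yl)ethyl on a nitrogen on an aromatic ring. Going by the values given here, no measured step bears on this change in a readable way. Compound 1, carrying the 3-hydroxycyclobutyl, gave only a limit. Compound 2, carrying the 2-(oxan-4-yl)ethyl, gave only a limit as well. The expectation for compound 3 therefore rests on two limits and nothing more. The step from compound 2 to compound 3 is expected to be an at least 1.2-fold lower number from compound 2 to compound 3 (0.09 log units; that floor lies within the scatter), with a large chance that the result is once more a limit. Compound 3 is estimated at 8000 nM, within 1500 nM to 40000 nM.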

Compound 3, half-maximal inhibitory concentration: 160 nM
For compound 3 the middle estimate is 50-fold (1.70 log units) above the measured one, outside the stated range (below it).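

In this assay, substituents on the nitrogen on an aromatic ring had so far given only limits, and the steps with a limit at both ends cannot be read: the limit of > 10000 nM in this assay, at which 2 of the 3 values shown sit.

For the compounds shown here, the 3-carbamoyl-2,2-dimethylcyclobutyl gives the first value at this place that is not a limit, with an at least 62-fold lower number from compound 2 to compound 3 (1.79 log units; beyond the scatter) on replacing 2-(oxan-4-yl)ethyl, and an at least 62-fold lower number from compound 1 to compound 3 (1.79 log units; beyond the scatter) on replacing (3-hydroxycyclobutyl)methyl. On the shared core, the read-out therefore responds strongly to the group on this nitrogen, which the two earlier compounds, both limits, could not show.

The compounds shown do not separate the contribution of the carbamoyl from that of the two methyl groups, the four-membered ring or the two defined stereocentres, all of which enter together in this change. Also open, as far as these compounds go, is whether a carboxylic acid or a methyl ester in place of the carbamoyl, or another stereoisomer of the cyclobutyl, would keep the read-out near that of compound 3 at 160 nM.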